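The source may hold more compounds than are shown below. What is called first, only, known or untested is meant among the compounds shown, and "the series" means these compounds.

Measured so far:
- compound 1, `COc1nc(C)c(Nc2nc(Cl)cn([C@H](COC(=O)c3ccccn3)C3CC3)c2=O)cc1C`: 67 nM
- compound 2, `COc1nc(C)c(Nc2nc(Cl)cn([C@H](COC(=O)Nc3ccc(Cl)cc3)C3CC3)c2=O)cc1C`: 1.6 nM
- compound 3, `CCNC(=O)OC[C@H](C1CC1)n1cc(Cl)nc(Nc2cc(C)c(OC)nc2C)c1=O`: 14 nM

In an assay on frontal cortex for displacement of a labelled ligand from corticotropin-releasing factor receptor 1 (Rattus norvegicus), with a stated time of 2 h (a higher number here means a weaker inhibitor, a lower number a stronger inhibitor), compound 3 stands second highest of the three numbers, a weaker inhibitor than compound 2 but a stronger one than compound 1. The gaps to both are beyond the scatter: an 8.8-fold higher number from compound 2 to compound 3 (0.94 log units; beyond the scatter) and, in the other direction, a 4.8-fold lower number from compound 1 to compound 3 (0.68 log units; beyond the scatter).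

Compound 4, `COc1nc(C)c(Nc2nc(Cl)cn([C@H](COc3ccccn3)C3CC3)c2=O)cc1C`, is made from compound 3 by the change (pyridin-2-yl in place of ethylcarbamoyl on an oxygen on a saturated carbon). The group that enters is the same pyridin-2-yl ring that sits on a carbonyl carbon in compound 1, but in compound 4 it sits directly on the oxygen, with no carbonyl between. Among the compounds with values here, no measured step swaps a group on that oxygen, so only indirect guidance exists: compound 1 with its pyridin-2-yl gives 67 nM, and the step of a 4.8-fold lower number from compound 1 to compound 3 (0.68 log units; beyond the scatter) shows that the ethylcarbamoyl group of compound 3 gave a modestly lower number. Removing it and placing the ring on the oxygen is therefore expected to move the number upward, toward the region of compound 1, by a modest step of a 2.9-fold higher number from compound 3 to compound 4 (0.46 log units; beyond the scatter).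

The estimate for compound 4 in this assay is 40 nM, with a range from 10 nM to 160 nM.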

Compound 4, half-maximal inhibitory concentration: 1.2 nM
Compound 4: the middle estimate sits 33-fold (1.52 log units) above what was measured, outside the stated range (below it).
By their numbers in this assay, from the lowest: compounds 4 and 2 (each within the scatter of the next); then compound 3; then compound 1.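

In this assay, the oxygen on a saturated carbon accepts an aromatic ring attached directly, with no carbamoyl group needed: pyridin-2-yl replacing ethylcarbamoyl gives a 12-fold lower number from compound 3 to compound 4 (1.07 log units; beyond the scatter). The link to the ring matters greatly, as removing only the carbonyl of (pyridin-2-yl)carbonyl gives a 56-fold lower number from compound 1 to compound 4 (1.75 log units; beyond the scatter). Two very different groups on this oxygen, pyridin-2-yl and (4-chlorophenyl)carbamoyl, also cannot be told apart here, with a 1.3-fold lower number from compound 2 to compound 4 (0.12 log units; within the scatter).

Nothing available explains what lies behind these shifts. Going by these compounds, whether a plain phenyl ring or a simple methyl group on the same oxygen would match pyridin-2-yl remains open, and so does whether the ring nitrogen of pyridin-2-yl counts for anything.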